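Sulfonyl group size on the pyridinone side chain

A few compounds are considered here, and "the series" means these few. Any claim that something is new, unique, unknown or untested is made for them only; others in the source may bear on it.

Measured compounds:
Compound 1, `CCCCc1ccc(CN)c(=O)n1Cc1ccc(-c2ccccc2-c2nn[nH]n2)cc1`, gives 20 nM in a functional assay (aorta) for antagonist activity, with Oryctolagus cuniculus as the target; on this read-out higher numbers stand for weaker inhibition and lower numbers for stronger inhibition.
Compound 2, `CCCCc1ccc(CNS(=O)(=O)c2ccccc2)c(=O)n1Cc1ccc(-c2ccccc2-c2nn[nH]n2)cc1`, gives 7 nM in this assay.
Compound 3, `CCCCc1ccc(CN(C)S(=O)(=O)c2ccc(C)cc2)c(=O)n1Cc1ccc(-c2ccccc2-c2nn[nH]n2)cc1`, gives 8 nM in this assay.

Compound 3 sits close to compound 2, since a 1.1-fold higher number from compound 2 to compound 3 (0.06 log units; within the scatter) stays within the scatter, and clearly below compound 1, since a 2.5-fold lower number from compound 1 to compound 3 (0.40 log units; beyond the scatter) lies beyond it. Among the compounds with values here, the only changes measured so far concern what is attached to the amine nitrogen of the shared core: a 2.9-fold lower number from compound 1 to compound 2 (0.46 log units; beyond the scatter) and a 2.5-fold lower number from compound 1 to compound 3 (0.40 log units; beyond the scatter) show that attaching an arylsulfonyl group, with or without an extra methyl on the nitrogen, gives a modest gain.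

Compound 4, `CCCCc1ccc(CN(C)S(C)(=O)=O)c(=O)n1Cc1ccc(-c2ccccc2-c2nn[nH]n2)cc1`, keeps the methylated sulfonamide of compound 3 but changes the sulfonyl substituent: methyl in place of 4-methylphenyl on a sulfonyl sulfur. Within the data shown here, no measured step bears directly on this swap; the measured steps only show that a sulfonyl-bearing nitrogen beats the free amine. Whether the gain depends on the aromatic ring or merely on the sulfonyl is open, so the expectation for compound 4 lies between compound 3 and compound 1, a small loss beyond the scatter, a 1.6-fold higher number from compound 3 to compound 4 (0.21 log units; within the scatter). Compound 4 is therefore estimated at 13 nM in this assay, with a range from 5 nM to 35 nM.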

Compound 4, half-maximal inhibitory concentration: 0.2 nM
Compound 4: the middle estimate sits 65-fold (1.81 log units) above what was measured, outside the stated range (below it).
By their numbers in this assay, from the lowest: compound 4; then compounds 2 and 3 (each within the scatter of the next); then compound 1.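

In this assay the swap of methyl for 4-methylphenyl on the sulfonyl sulfur gives a 40-fold lower number from compound 3 to compound 4 (1.60 log units; beyond the scatter), which shows that the group on the sulfur, and not only the presence of a sulfonyl, has a very strong bearing on the result at this position. The change of the whole side-chain group gives a 35-fold lower number from compound 2 to compound 4 (1.54 log units; beyond the scatter) and, measured against the free amine, a 100-fold lower number from compound 1 to compound 4 (2.00 log units; beyond the scatter), so an aromatic ring on the sulfonyl is not needed here, and the methylsulfonyl compound has the lowest number of the four, with its steps to all the others beyond the scatter. No supporting data are available to explain why methyl on the sulfur does so much better than 4-methylphenyl.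

Going by these compounds, the methylsulfonyl group appears here only on a methylated nitrogen, so it remains open whether the same low number would hold with a hydrogen on that nitrogen. On these data alone, it also remains open how far this result extends to other groups on the sulfur, such as ethyl, isopropyl or trifluoromethyl.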